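The source may report more compounds than this note shows. Statements on the series, on what has been measured and on what is new or still open speak of the compounds shown alone.

Compound 1 `CC(=O)c1ccc2c(c1)C(n1ccccc1=O)=CC(C)(C)O2` gives 7.37 in a functional assay (aorta) with Rattus norvegicus as the target; a higher number here means a more potent compound, by a factor of ten per unit of this negative logarithm, a lower number a less potent compound; compound 2 `CC1(C)C=C(n2ccccc2=O)c2cc(C(=O)c3ccccc3[N+](=O)[O-])ccc2O1` gives 6.17; compound 3 `Cc1ccccc1C(=O)c1ccc2c(c1)C(n1ccccc1=O)=CC(C)(C)O2` gives 6.83.

Compound 3 stands second highest of the three numbers, with a number 0.54 log units lower from compound 1 to compound 3 (beyond the scatter) and a number 0.66 log units higher from compound 2 to compound 3 (beyond the scatter). Compound 4 `CC1(C)C=C(n2ccccc2=O)c2cc(C(=O)c3ccccc3C(F)(F)F)ccc2O1` differs from compound 3 by trifluoromethyl in place of methyl on an aromatic carbon. Among the measured compounds shown here, no measured step shows trifluoromethyl entering. The nearest guidance is the exchange at the same aromatic carbon, a number 0.66 log units higher from compound 2 to compound 3 (beyond the scatter), together with the two aryl steps from compound 1, a number 1.20 log units lower from compound 1 to compound 2 (beyond the scatter) and a number 0.54 log units lower from compound 1 to compound 3 (beyond the scatter). Both aryl groups lowered the number, and the group now entering sits where nitro and methyl differed. A modest lowering is therefore expected, with compound 4 estimated at 6.5 (range 5.9 to 7.1). The expected step is a number 0.33 log units lower from compound 3 to compound 4 (beyond the scatter).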

Compound 4, logarithm of the reciprocal of the active concentration, log(1/C): 6.76
Estimate against measurement, compound 4: 0.26 log units below, and the stated range covers the measured number.
By their numbers in this assay, from the lowest: compound 2; then compounds 4 and 3 (each within the scatter of the next); then compound 1.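

In this assay trifluoromethyl and methyl on this aromatic carbon cannot be told apart, the step being a number 0.07 log units lower from compound 3 to compound 4 (within the scatter) while nitro at the same place stays apart, with a number 0.59 log units higher from compound 2 to compound 4 (beyond the scatter) as the step. On the carbonyl carbon, 2-(trifluoromethyl)phenyl still falls short of methyl, with a number 0.61 log units lower from compound 1 to compound 4 (beyond the scatter) as the step, so all three aryl groups shown give a lower number than methyl. No measurement at hand accounts for this ranking.

The compounds shown leave open what an amine or a carboxylic acid on this aromatic carbon would give, and where plain phenyl on the carbonyl carbon would stand.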